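Terminal benzimidazole substituent: ethyl shortened to methyl

The compounds below may be only part of what the source reports. "The series", "measured", "known", "first", "only" and "open" are said of these compounds alone.

Three linked benzimidazole compounds have been measured in a functional assay on RPMI 8402 cells (Homo sapiens) for cytotoxicity; a lower number here means a stronger inhibitor, a higher number a weaker inhibitor. Compound 1 `COc1ccc(-c2ccc3[nH]c(-c4ccc5[nH]c(-c6ccc7[nH]cnc7c6)nc5c4)nc3c2)cc1` gives 90 nM. Within the data shown here, compound 3 `c1ccc2cc(-c3ccc4[nH]c(-c5ccc6[nH]c(-c7ccc8[nH]cnc8c7)nc6c5)nc4c3)ccc2c1` gives 80 nM, and the single step of a 1.1-fold lower number from compound 1 to compound 3 (0.05 log units; within the scatter) shows that naphthalen-2-yl in place of 4-methoxyphenyl on an aromatic carbon leaves the number essentially where it was. Compound 2 `CCc1nc2cc(-c3nc4cc(-c5nc6cc(-c7ccccc7)ccc6[nH]5)ccc4[nH]3)ccc2[nH]1` gives 110 nM, the highest number of the three, though its gaps to compound 1 and to compound 3 both lie within the scatter.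

Compound 4 `Cc1nc2cc(-c3nc4cc(-c5nc6cc(-c7ccccc7)ccc6[nH]5)ccc4[nH]3)ccc2[nH]1` is not yet measured. It differs from compound 2 by hydrogen in place of methyl on a saturated chain carbon bound to an aromatic carbon, read one bond further out as ethyl to methyl on the 2-ethyl-1H-benzimidazol-5-yl terminus. Among the measured compounds shown here, no measured step touches this position: the only step available changes the aryl group at the opposite end of the shared core and stays within the scatter. With nothing to suggest a shift either way, the step of no change at the digits printed from compound 2 to compound 4 (within the scatter) is expected to remain within the scatter.

Compound 4 is therefore estimated at 110 nM in this assay, with a range of 55 nM to 220 nM.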

Compound 4, half-maximal inhibitory concentration: 110 nM
Beside the measured number, compound 4's estimate shows no gap at the digits printed; low and high end bracket the measured number.
By their numbers in this assay, from the lowest: compounds 3, 1, 2 and 4 (each within the scatter of the next).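

In this assay the 2-ethyl-1H-benzimidazol-5-yl terminus now has its first reading: no change at the digits printed from compound 2 to compound 4 (within the scatter) shows that ethyl to methyl leaves the number in place. Among these compounds, the only earlier step, naphthalen-2-yl in place of 4-methoxyphenyl, concerned a different part of the shared core, so this is the first sign that hydrogen in place of methyl on a saturated chain carbon bound to an aromatic carbon can pass without a change beyond the scatter, though it rests on this single pair. No supporting data are available to explain this flat step.

Still open, as far as these compounds go, is whether a longer chain such as n-butyl, an amine or a carboxylic acid at this terminus would move the number. One pair also cannot show whether the same flat step would hold with naphthalen-2-yl or 4-methoxyphenyl at the other end of the shared core.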